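The compounds below may be only part of what the source reports. "The series", "measured", "known", "first", "only" and "open" are said of these compounds alone.

Of the compounds shown here, three on a shared core have been measured in a functional assay on HeLa cells (Homo sapiens) for inhibition, read by sulforhodamine B assay; on this read-out higher numbers stand for weaker inhibition and lower numbers for stronger inhibition. Within the data shown here, compound 1 `O=C1C(Nc2ccccc2F)=CC(=O)c2c1nc1n2[C@H]2OC[C@@H](O)[C@H]2OC1` gives 9820 nM and compound 3 `O=C1C(NCc2ccccc2)=CC(=O)c2c1nc1n2[C@H]2OC[C@@H](O)[C@H]2OC1` gives 11000 nM, so compound 3 stands within the scatter of the only other exact number. Compound 2 `O=C1C(N2CCCCC2)=CC(=O)c2c1nc1n2[C@H]2OC[C@@H](O)[C@H]2OC1` reaches only a limit, > 16000 nM.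

The next compound to be tested is compound 4 `O=C1C(Nc2cccc(F)c2)=CC(=O)c2c1nc1n2[C@H]2OC[C@@H](O)[C@H]2OC1`, and the change leading to it is 3-fluorophenyl in place of benzyl on an amine nitrogen. The closest measured precedent is a 1.1-fold higher number from compound 1 to compound 3 (0.05 log units; within the scatter), which links a fluorophenyl group and benzyl on the same amine nitrogen, with the fluorine placed differently from compound 4. The two steps that rest on the limit, an at least 1.6-fold higher number from compound 1 to compound 2 (0.21 log units; that floor lies within the scatter) and an at least 1.4-fold lower number from compound 2 to compound 3 (0.16 log units; that floor lies within the scatter), exchange the whole amine substituent and add little to this comparison.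

Among the measured compounds shown here, with only this precedent to go on, no shift beyond the scatter is expected in this assay. The estimated change is a 1.2-fold lower number from compound 3 to compound 4 (0.06 log units; within the scatter), which would stay within the scatter. For compound 4 the expected value is 9500 nM, with an estimated range from 4500 nM to 17000 nM.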

Compound 4, half-maximal inhibitory concentration: > 8000 nM
Compound 4: only a limit was reported (the forecaster's own chance of this, stated with the estimate: 15%); the middle value is on the limit's open side.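

In this assay compound 4 is reported only as a limit, > 8000 nM. Its steps from compound 1, compound 2 and compound 3 therefore cannot be read. The compounds shown leave open where compound 4 stands relative to compound 1 and compound 3, and whether 3-fluorophenyl in place of 2-fluorophenyl on the amine nitrogen changes the read-out at all.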